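A Bromine Added to the Phenyl Ring of Compound 1

This account rests on a few compounds, and the source may have more. Where it says the series, first, only, none or still open, it means among the compounds named here.

Compound 1, `COc1cc(/C=N/Nc2nc(-c3ccccc3)cs2)c(Br)c(Br)c1OC`: 33600 nM
Compound 2, `COc1cc(/C=N/Nc2nc(-c3ccccc3)cs2)cc(Br)c1OC`: 68300 nM
Compound 3, `Fc1ccc(/C=N/Nc2nc(-c3cc(C(F)(F)F)cc(C(F)(F)F)c3)cs2)cc1F`: 16700 nM

All three compounds were tested in a functional assay on HepG2 cells (Homo sapiens) for inhibition, read by MTT assay, with a stated time of 48 h; on this read-out lower numbers stand for stronger inhibition and higher numbers for weaker inhibition. Compound 1 gives 33600 nM, the second highest of the three numbers. Its nearest neighbour is compound 3, which gives 16700 nM, a gap that lies within the scatter of the measurement, so no order between these two can be claimed. Among the compounds with values here, the only change of a single group among the measured compounds is the loss of a bromo from the core of compound 1 to give compound 2: a 2.0-fold higher number from compound 1 to compound 2 (0.31 log units; beyond the scatter).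

The unmeasured compound 4, `COc1cc(/C=N/Nc2nc(-c3ccc(Br)cc3)cs2)c(Br)c(Br)c1OC`, differs from compound 1 elsewhere, on the phenyl group: bromo in place of hydrogen on an aromatic carbon. Within the data shown here, no measured step touches that phenyl group, so the one step that exists, a 2.0-fold higher number from compound 1 to compound 2 (0.31 log units; beyond the scatter), bears on it only indirectly, and it is itself modest. A change of one bromo in another place moved the number by a modest amount, and nothing in the data suggests a larger effect here. For compound 4 the expectation is therefore no step beyond the scatter, with the estimated change a 1.2-fold lower number from compound 1 to compound 4 (0.08 log units; within the scatter). Compound 4 is estimated at 28000 nM, within a range from 9000 nM to 85000 nM.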

Compound 4, half-maximal inhibitory concentration: > 100000 nM
Compound 4: only a limit was reported; the forecaster's own chance of this, stated with the estimate: 5%; middle value at least 3.5-fold (0.55 log units) away from the limit.
By their numbers in this assay, from the lowest: compounds 3 and 1 (each within the scatter of the next); then compound 2. At a limit, above all of these: compound 4.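

The phenyl group of compound 1 turns out not to be a neutral place for change: one bromo on an aromatic carbon of that ring, para to a large group, gives an at least 2.9-fold higher number from compound 1 to compound 4 (0.47 log units; beyond the scatter), which in this assay means weaker inhibition. The earlier step on the core ran the other way in terms of bromo, since taking a bromo away gave a 2.0-fold higher number from compound 1 to compound 2 (0.31 log units; beyond the scatter), so there the bromo goes with the lower number, while on the phenyl group it goes with the higher one, and a bromo therefore has no single direction of effect across these two places in compound 1. For compound 4, the reported > 100000 nM is a limit of the assay and not a number, so the step has a minimum size but no known upper end: the limit of > 100000 nM in this assay, at which 1 of the 4 values shown sits.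

From the compounds shown here alone, what remains open is whether this carbon disfavours any added group or only the bromo, for example whether an amine, a hydroxyl or a carboxylic acid in the same place would also raise the number. Also open, going by these compounds, is whether the 4-bromophenyl change would act the same way on a different core substitution, such as that of compound 2.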